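Compound 2 to compound 4: a swap among limits

This account rests on a few compounds, and the source may have more. Where it says the series, first, only, none or still open, it means among the compounds named here.

Going by the values given here, the series so far holds compound 1 `CCN(CC)c1ccc(-c2cc(Cl)cn3c([N+](=O)[O-])c(CS(=O)(=O)c4ccccc4)nc23)cc1`, compound 2 `N#Cc1ccc(-c2cc(Cl)cn3c([N+](=O)[O-])c(CS(=O)(=O)c4ccccc4)nc23)cc1` and compound 3 `O=Cc1ccc(-c2cc(Cl)cn3c([N+](=O)[O-])c(CS(=O)(=O)c4ccccc4)nc23)cc1`, with compound 4 `O=[N+]([O-])c1c(CS(=O)(=O)c2ccccc2)nc2c(-c3cccc(F)c3)cc(Cl)cn12` still unmeasured. In an ADME assay on HepG2 cells (Homo sapiens) for cytotoxicity, read by MTT assay, with a stated time of 72 h (on this read-out higher numbers stand for lower toxicity in this test and lower numbers for higher toxicity in this test), compound 2 gives > 3900 nM, which is a limit and not a number. Compound 1 gives > 15600 nM, also a limit. Compound 3 gives > 31200 nM, again a limit. Compound 2 therefore has no exact place in the series, and neither of the other two values can rank it.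

The change to compound 4 is 3-fluorophenyl in place of 4-cyanophenyl on an aromatic carbon. Among the compounds with values here, three measured steps bear on it, each swapping one group on an aromatic carbon: a step that the two limits leave unreadable from compound 1 to compound 2, a step that the two limits leave unreadable from compound 1 to compound 3 and a step that the two limits leave unreadable from compound 2 to compound 3. None has a readable size, and none involves 3-fluorophenyl. No size or direction can be carried over to this assay, so compound 4 is simply expected to stay in the range spanned by the three limits, quite possibly as a limit itself. The expected step is a step that the limit leaves unreadable from compound 2 to compound 4. For compound 4 the estimate is 15000 nM, with an expected range from 4000 nM to 50000 nM.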

Compound 4, half-maximal cytotoxic concentration: > 12500 nM
Compound 4: no number, only a limit; the forecaster's own chance of this, stated with the estimate: 75%; the middle value does not contradict the limit.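

In this assay compound 4 gives > 12500 nM, which is a limit and not a number. Going by these compounds alone, compound 1, compound 2 and compound 3 are also held only as limits, so no step from any of them to compound 4 can be read. The compounds shown leave open whether 3-fluorophenyl, 4-cyanophenyl, 4-formylphenyl and 4-(diethylamino)phenyl differ at all in this assay.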